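This account rests on a few compounds, and the source may have more. Where it says the series, first, only, none or still open, it means among the compounds named here.

Working notes on the series, read in a toxicity assay on cells (Macrophage, Mus musculus, strain BALB/c) for cytotoxicity, read by MTT assay; a higher number here means a weaker inhibitor, a lower number a stronger inhibitor. Compound 1 (`C=CCOc1cc(OC)c(C(=O)/C=C/c2ccccn2)c(OCC=C)c1`) gives 12500 nM, compound 2 (`C=CCOc1cc(OC)c(C(=O)/C=C/c2ccccc2F)c(OCC=C)c1`) gives 13300 nM, and compound 3 (`C=CCOc1cc(OC)c(C(=O)/C=C/c2ccc(OC)cc2)c(OCC=C)c1`) gives 18700 nM. The three values form one cluster. Compound 3 stands within the scatter of both others, the steps being a 1.4-fold higher number from compound 2 to compound 3 (0.15 log units; within the scatter) and a 1.5-fold higher number from compound 1 to compound 3 (0.17 log units; within the scatter).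

The next step leads to compound 4 (`C=CCOc1cc(OC)c(C(=O)/C=C/c2ccc([N+](=O)[O-])cc2)c(OCC=C)c1`), and the change is nitro in place of methoxy on an aromatic carbon. This is nitro in place of methoxy on an aromatic carbon, para to a large group, so 4-methoxyphenyl becomes 4-nitrophenyl.

All measured steps exchange the group at this same end of the chain, which makes them the relevant guide. The third of them is a 1.1-fold higher number from compound 1 to compound 2 (0.03 log units; within the scatter), so none of the three leaves the scatter. Among the measured compounds shown here, no measured compound carries nitro, so the series offers no direct reading on this group, and that widens the range. In this assay, no step beyond the scatter is therefore expected, and the estimated step is a 1.3-fold lower number from compound 3 to compound 4 (0.13 log units; within the scatter). Compound 4 is expected at 14000 nM, with an estimated range of 7000 nM to 26000 nM.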

Compound 4, half-maximal inhibitory concentration: 13200 nM
Compound 4: middle estimate off by 1.1-fold (0.03 log units), on the high side; low and high end bracket the measured number.
By their numbers in this assay, from the lowest: compounds 1, 4, 2 and 3 (each within the scatter of the next).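

Compound 4 brings a new group to this end of the chain, and in this assay nitro in place of methoxy on an aromatic carbon, para to a large group, stays within the scatter (a 1.4-fold lower number from compound 3 to compound 4 (0.15 log units; within the scatter)). The comparisons with the other two aromatic ends also stay within the scatter (a 1.0-fold lower number from compound 2 to compound 4 (0.00 log units; within the scatter); a 1.1-fold higher number from compound 1 to compound 4 (0.02 log units; within the scatter)), so 4-nitrophenyl joins pyridin-2-yl, 2-fluorophenyl and 4-methoxyphenyl in a single cluster, and none of the four compounds goes against this pattern. No supporting evidence accompanies these numbers, so the flat reading at this position remains an observation about these four compounds alone.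

The compounds shown leave open whether a group of another kind at this end, such as an amine or a carboxylic acid on the phenyl ring, would stay in the cluster or leave it. Going by these compounds, all four compounds also share the same core with its methoxy group and two ether chains, so the effect of a change there, such as a longer chain in place of either ether chain, remains open.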